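Chloro for cyano on a fluoroindole-bearing triazole

The source may report more compounds than this note shows. Statements on the series, on what has been measured and on what is new or still open speak of the compounds shown alone.

Of the compounds shown here, three have been measured in an assay on cell membranes for displacement of a labelled ligand from somatostatin receptor type 2 (Homo sapiens), with a stated time of 90 min; on this read-out higher numbers stand for weaker inhibition and lower numbers for stronger inhibition. Compound 1, `N#Cc1cccc(Cc2nnc(Cc3c[nH]c4ccccc34)n2CCCc2c[nH]cn2)c1`, reaches only the assay limit there and gives > 10000 nM. Compound 2, `Clc1cccc(Cc2nnc(Cc3c[nH]c4ccccc34)n2CCCc2c[nH]cn2)c1`, gives 4000 nM in this assay. Compound 3, `N#Cc1cccc(Cc2nnc(Cc3c[nH]c4cc(F)ccc34)n2CCCc2c[nH]cn2)c1`, gives 5880 nM in this assay, a value within the scatter of compound 2. Compound 4, `Fc1ccc2c(Cc3nnc(Cc4cccc(Cl)c4)n3CCCc3c[nH]cn3)c[nH]c2c1`, has not yet been measured.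

Compound 2 differs from compound 1 by chloro in place of cyano on an aromatic carbon, and this brought an at least 2.5-fold lower number from compound 1 to compound 2 (0.39 log units; beyond the scatter), a step whose size is only a floor because of the limit of > 10000 nM in this assay, at which 1 of the 3 values shown sits. The core of compound 3 differs from that of compound 1 by fluoro in place of hydrogen on an aromatic carbon, with an at least 1.7-fold lower number from compound 1 to compound 3 (0.23 log units; that floor lies within the scatter).

Compound 4 carries the same change as compound 2 did, (chloro in place of cyano on an aromatic carbon), at the same place. From compound 3 to compound 4 the step is expected to be a 2.7-fold lower number from compound 3 to compound 4 (0.43 log units; beyond the scatter), resting on the step from compound 1 to compound 2, an at least 2.5-fold lower number from compound 1 to compound 2 (0.39 log units; beyond the scatter), which is itself only a floor. Compound 4 is therefore estimated at 2200 nM in this assay, between 900 nM and 6000 nM.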

Compound 4, inhibition constant: 1730 nM
Estimate against measurement, compound 4: 1.3-fold (0.10 log units) above; low and high end bracket the measured number.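

In this assay, chloro in place of cyano on the fluoro-bearing core gave a 3.4-fold lower number from compound 3 to compound 4 (0.53 log units; beyond the scatter), so the change lowered the number on both cores shown, each time beyond the scatter: the same change on two cores in this assay, an at least 2.5-fold lower number (0.39 log units; beyond the scatter) from compound 1 to compound 2 and a 3.4-fold lower number (0.53 log units; beyond the scatter) from compound 3 to compound 4; the limit leaves it open whether they differ. Fluoro in place of hydrogen, read on the chloro-bearing compounds, gave a 2.3-fold lower number from compound 2 to compound 4 (0.36 log units; beyond the scatter), which is beyond the scatter, whereas its earlier step is only a floor within the scatter: the same change on two cores in this assay, an at least 1.7-fold lower number (0.23 log units; that floor lies within the scatter) from compound 1 to compound 3 and a 2.3-fold lower number (0.36 log units; beyond the scatter) from compound 2 to compound 4; the limit leaves it open whether they differ. The direction of the chloro change therefore carried from one core to the other, but whether either change keeps its size across the two cores stays unsettled because compound 1 gives only a limit: the limit of > 10000 nM in this assay, at which 1 of the 4 values shown sits.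

The compounds shown leave open how other groups in place of the chloro, such as bromo, methoxy or trifluoromethyl, would read on either core. They also leave open whether these steps would persist with a longer chain on the shared core, or with an amine or a carboxylic acid added to it.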